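This account rests on a few compounds, and the source may have more. Where it says the series, first, only, none or still open, it means among the compounds named here.

Working notes on the series in a functional assay on HepG2 cells (Homo sapiens) for inhibition, read by MTT assay, with a stated time of 3 days; on this read-out higher numbers stand for weaker inhibition and lower numbers for stronger inhibition: compound 1 `COc1cc(-c2nc3ccccc3s2)ccc1OCC(=O)NNC(=O)CN[C@@H](CS(=O)(=O)O)C(=O)O` gives 3690 nM, compound 2 `COc1cc(-c2nc3ccccc3s2)ccc1OCC(=O)NNC(=O)CN1CCC[C@H]1C(=O)O` gives 2650 nM, and compound 3 `CCOC(=O)[C@H](CS)NCC(=O)NNC(=O)COc1ccc(-c2nc3ccccc3s2)cc1OC` gives 3760 nM. Compound 3 cannot be separated from the other two, as all three numbers lie within the scatter of one another.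

Compound 4 `CCOC(=O)[C@@H]1CCCN1CC(=O)NNC(=O)COc1ccc(-c2nc3ccccc3s2)cc1OC` differs from compound 3 on a saturated chain carbon bound to a carbonyl carbon: 2-(ethoxycarbonyl)pyrrolidin-1-yl in place of (1-(ethoxycarbonyl)-2-sulfanylethyl)amino on a saturated chain carbon bound to a carbonyl carbon. It carries the ethyl ester of the 2-carboxypyrrolidin-1-yl group found in compound 2.

For the measured compounds named here, three measured steps bear on this change: a 1.4-fold lower number from compound 1 to compound 2 (0.14 log units; within the scatter), a 1.0-fold higher number from compound 1 to compound 3 (0.01 log units; within the scatter) and a 1.4-fold higher number from compound 2 to compound 3 (0.15 log units; within the scatter). Each exchanges the group at this place, and none leaves the scatter. Going by the values given here, no pair of measured compounds isolates the ester on the pyrrolidine, so that part remains untested. In this assay, no step beyond the scatter is therefore expected, and no direction can be assigned.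

The expected change is a 1.3-fold lower number from compound 3 to compound 4 (0.10 log units; within the scatter). Compound 4 is estimated at 3000 nM, with an expected range of 1400 nM to 6500 nM.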

Compound 4, half-maximal inhibitory concentration: 2800 nM
Compound 4: the middle estimate sits 1.1-fold (0.03 log units) above what was measured, and the stated range covers the measured number.
By their numbers in this assay, from the lowest: compounds 2, 4, 1 and 3 (each within the scatter of the next).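

In this assay the ethyl ester on the pyrrolidine, untested until now, gives a 1.1-fold higher number from compound 2 to compound 4 (0.02 log units; within the scatter), so that ester and the free carboxylic acid cannot be told apart here. The 2-(ethoxycarbonyl)pyrrolidin-1-yl group also stays within the scatter of both amino groups it is compared with, giving a 1.3-fold lower number from compound 3 to compound 4 (0.13 log units; within the scatter) and a 1.3-fold lower number from compound 1 to compound 4 (0.12 log units; within the scatter). Across these four compounds, the place on a saturated chain carbon bound to a carbonyl carbon therefore carries ring and no-ring groups, ester and acid, sulfanyl and sulfo, with no step beyond the scatter.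

Open, going by these compounds, is whether any group at this place leaves the scatter, for instance a plain primary amine or a longer alkyl chain. No supporting information bears on this result.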